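Chloro to Trifluoromethyl on the Aryl Urea of Compound 1

A few compounds are considered here, and "the series" means these few. Any claim that something is new, unique, unknown or untested is made for them only; others in the source may bear on it.

Measured so far:
compound 1, `CCN1CCc2c(sc(NC(=O)Nc3ccc(Cl)cc3)c2C(N)=O)C1` — 3120 nM
compound 2, `CC(C)(C)OC(=O)CCN1CCc2c(sc(NC(=O)Nc3ccc(Cl)cc3)c2C(N)=O)C1` — 1100 nM

Among the measured compounds shown here, compound 1 has the highest of the two numbers in a functional assay (strain AB) with Danio rerio as the target, read by microscopy, with a stated time of 1 h; a lower number here means that less compound is needed, a higher number that more compound is needed for the effect; the only other measured compound, compound 2, sits below it, as the step of a 2.8-fold lower number from compound 1 to compound 2 (0.45 log units; beyond the scatter) shows. That step concerns a change at the chain attached to the ring amine, far from the aryl urea end of the shared core.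

Compound 3, `CCN1CCc2c(sc(NC(=O)Nc3ccc(C(F)(F)F)cc3)c2C(N)=O)C1`, differs from compound 1 elsewhere: trifluoromethyl in place of chloro on an aromatic carbon. For the measured compounds named here, no measured step touches the aryl ring or its substituent, so the recorded data give no direction for this change. Compound 2 and its step are not informative about a swap on the aromatic ring, and nothing else is known here.

The expectation for compound 3 therefore rests only on compound 1 itself, with a change of unknown effect: compound 3 is expected to give 3000 nM, within a range of 800 nM to 12000 nM, which means an estimated step of a 1.0-fold lower number from compound 1 to compound 3 (0.02 log units; within the scatter), not clearly beyond the scatter in either direction.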

Compound 3, half-maximal effective concentration: 2910 nM
Estimate against measurement, compound 3: 1.0-fold (0.01 log units) above; measured number inside the range.
By their numbers in this assay, from the lowest: compound 2; then compounds 3 and 1 (each within the scatter of the next).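

Among the compounds shown here, the aryl end of the shared core is touched here for the first time, and in this assay trifluoromethyl in place of chloro gives a 1.1-fold lower number from compound 1 to compound 3 (0.03 log units; within the scatter). For the compounds shown here, this place on the aromatic ring, para to a large group, therefore takes four heavy atoms instead of one with the two numbers staying within the scatter of each other, so this assay does not tell these two groups apart; the only earlier step, a 2.8-fold lower number from compound 1 to compound 2 (0.45 log units; beyond the scatter), lay beyond the scatter but concerned the chain on the ring amine. No measurement on hand offers an explanation for this result.

On these data alone, whether an amine, a carboxylic acid or a methoxy group at this same place would give a number beyond the scatter stays open, as a match between two groups says little about the others that could sit there. Also open, as far as these compounds go, is whether trifluoromethyl and chloro would again stay this close on compound 2, which carries the tert-butoxycarbonyl group on its chain.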